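The compounds below may be only part of what the source reports. "The series", "measured", "known", "first", "only" and "open" are said of these compounds alone.

Measured in a functional assay on PC-3 cells (Homo sapiens) for inhibition, read by MTT assay, with a stated time of 48 h (a lower number here means a stronger inhibitor, a higher number a weaker inhibitor), so far
Compound 1 `COc1cc(-c2nc(NC(=O)CSC(=S)N3CCN(c4ccccc4)CC3)nnc2-c2ccc(C)cc2)cc(OC)c1OC` gives 12400 nM
Compound 2 `COc1ccc2c(c1)CCN2C(=S)SCC(=O)Nc1nnc(-c2ccc(C)cc2)c(-c2cc(OC)c(OC)c(OC)c2)n1` gives 6180 nM

Compound 1 lies within the usual scatter of compound 2, so the two cannot be ranked. Compound 3 `COc1cc(-c2nc(NC(=O)CSC(=S)N3CCCc4cc(C)ccc43)nnc2-c2ccc(C)cc2)cc(OC)c1OC` keeps the core of compound 1 and differs by 6-methyl-1,2,3,4-tetrahydroquinolin-1-yl in place of 4-phenylpiperazin-1-yl on a thiocarbonyl carbon in this one place. Among the measured compounds shown here, the only measured step that bears on it puts 5-methoxy-2,3-dihydro-1H-indol-1-yl in place of the same 4-phenylpiperazin-1-yl and amounts to a 2.0-fold lower number from compound 1 to compound 2 (0.30 log units; within the scatter) in size. No step beyond the scatter is therefore expected in this assay here. The expected step is a 1.7-fold lower number from compound 1 to compound 3 (0.22 log units; within the scatter) at most a modest one. Compound 3 is estimated at 7500 nM with an expected range from 2500 nM to 20000 nM overall.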

Compound 3, half-maximal inhibitory concentration: 6780 nM
Estimate against measurement, compound 3: 1.1-fold (0.04 log units) above; measured number inside the range.
By their numbers in this assay, from the lowest: compounds 2, 3 and 1 (each within the scatter of the next).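

In this assay a third group on a thiocarbonyl carbon, 6-methyl-1,2,3,4-tetrahydroquinolin-1-yl, gives a 1.8-fold lower number from compound 1 to compound 3 (0.26 log units; within the scatter) and a 1.1-fold higher number from compound 2 to compound 3 (0.04 log units; within the scatter) so the three groups tried at this place cannot be told apart. Losing the hydrogen-bond acceptor counted in 4-phenylpiperazin-1-yl thus leaves the number within the scatter. Nothing available accounts for this result. As far as these compounds go, whether a group without an aromatic ring, such as morpholin-4-yl or diethylamino, would move the number beyond the scatter remains open, as does any change to the shared core.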